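A few compounds are considered here, and "the series" means these few. Any claim that something is new, unique, unknown or untested is made for them only; others in the source may bear on it.

The measured compounds so far:

Compound 1, `C=CCc1ccc(OCc2ccccc2)c(-c2ccc(O)c(CC=C)c2)c1`, gives 24000 nM in a functional assay on CNE2Z cells (Homo sapiens) for inhibition, read by MTT assay, with a stated time of 72 h; a higher number here means a weaker inhibitor, a lower number a stronger inhibitor.
Compound 2, `C=CCc1ccc(OCc2ccc(Cl)cc2Cl)c(-c2ccc(OCc3ccc(Cl)cc3Cl)c(CC=C)c2)c1`, gives only a limit, > 50000 nM, in this assay.
Compound 3, `C=CCc1ccc(OCc2ccc(Cl)c(Cl)c2)c(-c2ccc(OCc3ccc(Cl)c(Cl)c3)c(CC=C)c2)c1`, also gives only a limit, > 50000 nM, in this assay.

Compound 2 thus stands at the edge of what this assay can report: it shares that position with compound 3 (the limit of > 50000 nM in this assay, at which 2 of the 3 values shown sit), and of the three compounds only compound 1 returns an actual number. Compound 1 is the one with a single hydroxy left free, while compound 2 and compound 3 carry an ether on both oxygens.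

Compound 4, `C=CCc1ccc(O)c(-c2ccc(OCc3ccc(Cl)cc3Cl)c(CC=C)c2)c1`, is the next compound to be tested. It differs from compound 2 in one place: hydrogen in place of 2,4-dichlorobenzyl on an oxygen on an aromatic ring. The result is a compound that, like compound 1, keeps one hydroxy free and one oxygen as an ether.

For the measured compounds named here, no step between measured compounds is available here. Compound 2 gives a limit rather than a number. The expectation rests instead on compound 1, which with its one free hydroxy gives 24000 nM. Compound 4 is therefore expected to come back as a number rather than a limit, around 25000 nM, with a plausible range from 8000 nM to 60000 nM. That would mean an expected step of an at least 2.0-fold lower number from compound 2 to compound 4 (0.30 log units; that floor lies within the scatter), towards a stronger inhibitor.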

Compound 4, half-maximal inhibitory concentration: 11300 nM
Beside the measured number, compound 4's estimate is 2.2-fold (0.34 log units) above it; the range from low to high includes it.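

In this assay, taking the 2,4-dichlorobenzyl off one oxygen and leaving a hydroxy there brings the compound into the range where the assay reports a number: compound 4 gives 11300 nM. The change amounts to an at least 4.4-fold lower number from compound 2 to compound 4 (0.64 log units; beyond the scatter), so the second 2,4-dichlorobenzyl group is not needed for activity in these cells, and its replacement by hydrogen goes with a stronger inhibitor. The true size of this step stays unknown, because compound 2 has a limit and not a number, which makes the step a floor only: the limit of > 50000 nM in this assay, at which 2 of the 4 values shown sit.

The compounds shown leave open whether the gain comes from the free hydroxy itself or simply from the loss of the large 2,4-dichlorobenzyl group, a question that a small methyl ether or an amine on the same ring position could help to settle. They also leave open how far this position can be taken in other directions, for example with a short chain ending in a carboxylic acid on that oxygen.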